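Swapping Fluoro for Methoxy: Expected Efficacy of Compound 3

The source may hold more compounds than are shown below. What is called first, only, known or untested is meant among the compounds shown, and "the series" means these compounds.

Compound 1 `CCC(c1ccccc1)c1nc(-c2ccc(Cl)cc2)c(CC(=O)O)s1` gives 50% in an in vitro functional assay on HEK285-7 cells for antagonist activity at prostaglandin D2 receptor 2 (Homo sapiens), read by BRET and beta-arrestin recruitment; a lower number here means a smaller maximal response, a higher number a larger maximal response.
Compound 2 `O=C(O)Cc1sc(C(c2ccccc2)c2ccc(F)cc2)nc1-c1ccc(Cl)cc1` gives 80% in this assay.

Compound 2 stands highest of the two numbers; the nearest, compound 1, lies lower by the step of a number 30 percentage points higher from compound 1 to compound 2 (beyond the scatter). Compound 3 `COc1ccc(C(c2ccccc2)c2nc(-c3ccc(Cl)cc3)c(CC(=O)O)s2)cc1` differs from compound 2 by methoxy in place of fluoro on an aromatic carbon. For the measured compounds named here, no measured step covers this change: the only known step, a number 30 percentage points higher from compound 1 to compound 2 (beyond the scatter), concerns 4-fluorophenyl in place of ethyl and tells nothing about methoxy in place of fluoro. Compound 3 is therefore expected to show a step of only no change at the digits printed from compound 2 to compound 3 (within the scatter), not beyond the scatter. Compound 3 is estimated at 80% in this assay, within 60% to 95%.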

Compound 3, largest response reached (reported as efficacy), in percent of the reference or control that the assay uses: 80%
Beside the measured number, compound 3's estimate shows no gap at the digits printed, within the range that was stated.
By their numbers in this assay, from the lowest: compound 1; then compounds 2 and 3 (each within the scatter of the next).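

Methoxy in place of fluoro on this aromatic carbon, para to a large group, gives no change at the digits printed from compound 2 to compound 3 (within the scatter) in this assay, so two heavy atoms and a hydrogen-bond acceptor are tolerated here where one fluorine stood. With 4-methoxyphenyl in place of ethyl, the result is a number 30 percentage points higher from compound 1 to compound 3 (beyond the scatter), which shows that the rise seen with 4-fluorophenyl does not require fluoro. Nothing available explains why the two groups read alike. Going by these compounds, whether an amine or a longer alkoxy chain on this carbon would keep the response remains open, as does the effect of moving methoxy elsewhere on the ring.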